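Solubility notes on the shared-core series, toward compound 3

The source may report more compounds than this note shows. Statements on the series, on what has been measured and on what is new or still open speak of the compounds shown alone.

compound 1 `COc1ccc(F)cc1CNCCCNc1ccnc2cc(Cc3ccc(C#N)cc3)ccc12`: 4200 nM
compound 2 `COc1ccc(-c2ccc3c(NCCCNCc4cc(F)ccc4OC)ccnc3c2)cc1`: 32000 nM

Among the measured compounds shown here, in a physicochemical assay for solubility, with a stated time of 18 h, at pH 7.4 (on this read-out lower numbers stand for lower solubility and higher numbers for higher solubility), compound 2 stands highest of the two numbers; the only measured step in the set is a 7.6-fold higher number from compound 1 to compound 2 (0.88 log units; beyond the scatter). Compound 3 `COc1ccc(F)cc1CNCCCNc1ccnc2cc(-c3ccc(C(C)(C)C)cc3)ccc12` differs from compound 2 by tert-butyl in place of methoxy on an aromatic carbon. For the measured compounds named here, that earlier step also sat on the same aromatic carbon, but it exchanged the whole substituent, and no measured pair swaps methoxy for tert-butyl, so the size of the step is uncertain. A decrease in this assay is expected for compound 3, around a 3.2-fold lower number from compound 2 to compound 3 (0.51 log units; beyond the scatter). Compound 3 is estimated at 10000 nM, within 2500 nM to 40000 nM.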

Compound 3, solubility: 32000 nM
The estimate for compound 3 lay 3.2-fold (0.51 log units) below the measured number; measured number inside the range.
By their numbers in this assay, from the lowest: compound 1; then compounds 2 and 3 (each within the scatter of the next).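

In this assay tert-butyl in place of methoxy on this aromatic carbon gives no change at the digits printed from compound 2 to compound 3 (within the scatter) and so leaves the number of compound 2 in place. With a 7.6-fold higher number from compound 1 to compound 3 (0.88 log units; beyond the scatter) alongside it, the rise from 4-cyanobenzyl appears with 4-(tert-butyl)phenyl as well as 4-methoxyphenyl, so in these compounds it does not depend on the methoxy oxygen. No supporting data bear on the cause of either result.

Still open, on these data alone, is whether an amine or a carboxylic acid at this place on the phenyl ring would hold the number. The compounds shown also leave open how much of the rise belongs to the nitrile and how much to the benzyl carbon.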